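This account rests on a few compounds, and the source may have more. Where it says the series, first, only, none or still open, it means among the compounds named here.

Series notes, urea linker with pyridin-4-ylmethyl or pyrazolylmethyl on one side and a para-substituted phenyl on the other, read in an assay on isolated protein for activation of Nicotinamide phosphoribosyltransferase (Homo sapiens); a higher number here means that more compound is needed for the effect, a lower number that less compound is needed.

Three compounds carry a number. Compound 1 `O=C(NCc1ccncc1)Nc1ccc(S(=O)(=O)c2ccccc2Cl)cc1` gives 79 nM in this assay and stands lowest of the three. Compound 3 `CCOC(=O)c1ccc(N/C(=N\C#N)NCc2ccncc2)cc1`, with a cyanoguanidine in place of the urea and an ethyl ester on the phenyl, gives 41400 nM. Compound 2 `CCOC(=O)c1ccc(NC(=O)NCc2cc[nH]n2)cc1`, with the pyrazolylmethyl side chain and the same ethyl ester, gives 69000 nM. Both of these sit far from compound 1, well beyond the scatter, so the sulfonyl-bearing phenyl of compound 1 is the only arrangement here that reaches a low number.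

Compound 4 `CCN(CC)S(=O)(=O)c1ccc(NC(=O)NCc2ccncc2)cc1` is not yet measured. It differs from compound 1 in one place: diethylamino in place of 2-chlorophenyl on a sulfonyl sulfur. The aryl sulfone is thereby turned into a dialkyl sulfonamide while the urea and the pyridin-4-ylmethyl side are kept.

Going by the values given here, no step between measured compounds covers this change, and nothing in the set shows a sulfonamide. Among the compounds with values here, since the only low number in the set belongs to compound 1 with its aryl sulfone, and compounds 2 and 3 without it are far weaker, a rise in the number beyond the scatter is expected, though smaller than the gap to those two. The step from compound 1 to compound 4 is estimated as a 10-fold higher number from compound 1 to compound 4 (1.01 log units; beyond the scatter). For compound 4 the expected value in this assay is 800 nM, within a range of 150 nM to 5000 nM.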

Compound 4, half-maximal effective concentration: 384 nM
Estimate against measurement, compound 4: 2.1-fold (0.32 log units) above; the measured number falls inside the stated range.
By their numbers in this assay, from the lowest: compound 1; then compound 4; then compounds 3 and 2 (each within the scatter of the next).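

In this assay, the change at the sulfonyl sulfur can now be read directly: diethylamino in place of 2-chlorophenyl gives a 4.9-fold higher number from compound 1 to compound 4 (0.69 log units; beyond the scatter), a modest step that is nonetheless beyond the scatter. Compound 4 still gives 384 nM with no ring on that sulfur, so on this urea and pyridin-4-ylmethyl framework a number in this range does not depend on an aromatic ring at the position, and a sulfonamide can stand in place of the aryl sulfone. No measurement at hand explains the size of this step.

The swap changes several things at once, removing the ring and the chlorine and placing a nitrogen on the sulfur, so the compounds shown do not separate the share of each in the step. A plain phenyl would isolate the chlorine, cyclohexyl would test a non-aromatic ring attached through carbon, and piperidin-1-yl or morpholin-4-yl would show whether tying the two ethyl arms of the diethylamino group into a ring moves the number in either direction.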